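The source may hold more compounds than are shown below. What is called first, only, known or untested is meant among the compounds shown, and "the series" means these compounds.

Compound 1 `O=C(Oc1ccc(-c2cncn2C2CCN(C(=O)c3ccc(Cl)c(C(F)(F)F)c3)CC2)cc1)c1ccccc1` is one of two analogues of the shared core for which a result exists. In an assay on HEK293 cells for antagonist activity at P2X purinoceptor 7 (Homo sapiens), read by fluorescence, with a stated time of 2 h (a lower number here means a stronger inhibitor, a higher number a weaker inhibitor), compound 1 gives > 10000 nM, and this is a limit of the assay rather than a number. Compound 2 `O=C(c1ccc(Cl)c(C(F)(F)F)c1)N1CCC(n2cncc2-c2ccc(OS(=O)(=O)c3cccc4ccccc34)cc2)CC1` is the other. In this assay compound 2 gives 3520 nM, the only true number among the two results shown. The remaining entry is the limit of > 10000 nM in this assay, at which 1 of the 2 values shown sits.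

Compound 3 `CNC(=O)c1cccc(S(=O)(=O)Oc2ccc(-c3cncn3C3CCN(C(=O)c4ccc(Cl)c(C(F)(F)F)c4)CC3)cc2)c1` is not yet measured. It differs from compound 2 by 3-(methylcarbamoyl)phenyl in place of naphthalen-1-yl on a sulfonyl sulfur. For the measured compounds named here, no step between measured compounds of this kind has been recorded, so the direction of the change cannot be read from the data. A modest loss beyond the usual scatter is expected, amounting to a 1.7-fold higher number from compound 2 to compound 3 (0.23 log units; within the scatter). Compound 3 is accordingly estimated at 6000 nM in this assay, with a likely range from 1500 nM to 20000 nM.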

Compound 3, half-maximal inhibitory concentration: 112 nM
Compound 3: middle estimate off by 54-fold (1.73 log units), on the high side; the measured number lies below the stated range.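

Swapping naphthalen-1-yl for 3-(methylcarbamoyl)phenyl on a sulfonyl sulfur gives a 31-fold lower number from compound 2 to compound 3 (1.50 log units; beyond the scatter) in this assay, so the group at this position can strongly change the result. For the compounds shown here, the two earlier compounds provided no step of this kind, and this pair is the first to show the size of a change here. Compound 1 remains at a limit of the assay rather than a number: the limit of > 10000 nM in this assay, at which 1 of the 3 values shown sits.

The step changes two things at once, going from two aromatic rings to one and adding the methylcarbamoyl group, and the compounds shown cannot separate these changes or give a cause for the step. A plain phenyl on the sulfonyl sulfur would separate them, while a carboxylic acid or a nitrile in place of the methylcarbamoyl group would test whether the amide itself matters.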